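Replacing one side group on compound 1

A few compounds are considered here, and "the series" means these few. Any claim that something is new, unique, unknown or untested is made for them only; others in the source may bear on it.

Among the compounds with values here, in a functional assay on KB cells (Homo sapiens) for inhibition (on this read-out lower numbers stand for stronger inhibition and higher numbers for weaker inhibition), compound 1 `N#C/N=C(\N)c1cn([C@@H]2O[C@H](CO)[C@@H](O)[C@H]2O)c2nnnc(N)c12` gives 5000 nM, the only actual number among the three compounds measured so far. Compound 2 `CN(N)c1nnnc2c1c(C#N)cn2[C@@H]1O[C@H](COC(=O)c2ccccc2)[C@@H](OC(=O)c2ccccc2)[C@H]1OC(=O)c1ccccc1` reads > 10000 nM, which is a limit of the assay. Compound 3 `NC(=O)c1cn([C@@H]2O[C@H](COC(=O)c3ccccc3)[C@@H](OC(=O)c3ccccc3)[C@H]2OC(=O)c2ccccc2)c2nnnc(O)c12` reads > 10000 nM, which is also a limit. The remaining readings therefore come down to the limit of > 10000 nM in this assay, at which 2 of the 3 values shown sit, and neither offers a number to set against compound 1.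

Compound 4 `NC(=S)c1cn([C@@H]2O[C@H](CO)[C@@H](O)[C@H]2O)c2nnnc(N)c12` has not yet been measured in this assay. It differs from compound 1 at a single place, on an aromatic carbon of a five-membered aromatic ring with 1 nitrogen: a group of 3 heavy atoms (1 carbon, 1 nitrogen, 1 sulfur; no ring) in place of a group of 5 heavy atoms (2 carbon, 3 nitrogen; no ring), on an aromatic carbon. In words, a group of 3 heavy atoms takes the place of a group of 5 heavy atoms.

Within the data shown here, no measured pair of compounds isolates a swap of this kind, so the expectation starts from compound 1 at 5000 nM and stays uncertain. A moderate move toward stronger inhibition is expected, though a result close to compound 1 or weaker would not be surprising. The expected change is a 2.5-fold lower number from compound 1 to compound 4 (0.40 log units; beyond the scatter). For compound 4 the estimated value is 2000 nM, with an expected range of 200 nM to 10000 nM.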

Compound 4, half-maximal inhibitory concentration: 2000 nM
For compound 4 middle estimate and measured number coincide at the digits printed; the range from low to high includes it.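

In this assay, within the data shown here, the swap on the aromatic carbon gives a 2.5-fold lower number from compound 1 to compound 4 (0.40 log units; beyond the scatter), and this is the first comparison in the set that rests on two actual numbers. It shows that this position accepts a change: the group of 3 heavy atoms, which holds 1 sulfur and no triple bond, takes the place of the group of 5 heavy atoms, and inhibition is modestly stronger rather than lost. The side group on this aromatic carbon can therefore become smaller while the rest of compound 1 stays the same, something the compounds that read only as limits could not show: the limit of > 10000 nM in this assay, at which 2 of the 4 values shown sit.

A single swap cannot tell whether the sulfur, the smaller group or the missing triple bond accounts for the step, so no cause can be read from it. The compounds shown also leave open how a carboxylic acid, an amine or a longer chain on this aromatic carbon would read in this assay with the rest of compound 1 unchanged.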